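Swapping a carboxy for trifluoromethoxy on a styryl sulfone

This account rests on a few compounds, and the source may have more. Where it says the series, first, only, none or still open, it means among the compounds named here.

Measured compounds:
- compound 1, `COc1ccc(/C=C/S(=O)(=O)Cc2ccc(OC)cc2)cc1`: > 20000 nM
- compound 2, `COc1cc(OC)c(/C=C/S(=O)(=O)Cc2ccc(C(=O)O)cc2)c(OC)c1`: 15000 nM
- compound 3, `COc1ccc(CS(=O)(=O)/C=C/c2cc(OC)ccc2OC)cc1`: > 20000 nM

All three were tested in a functional assay on DLD-1 cells (Homo sapiens) for antiproliferative activity, read by trypan blue exclusion; on this read-out lower numbers stand for stronger inhibition and higher numbers for weaker inhibition. Compound 2 gives 15000 nM and is the only one of the three with a definite number. For compound 1 the result is a limit of the assay, > 20000 nM. For compound 3 the result is likewise a limit, > 20000 nM. So compound 2 stands as the sole measured value, with the other two sitting at the limit of > 20000 nM in this assay, at which 2 of the 3 values shown sit.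

Compound 4, `COc1cc(OC)c(/C=C/S(=O)(=O)Cc2ccc(OC(F)(F)F)cc2)c(OC)c1`, has not yet been measured. It differs from compound 2 in one place: trifluoromethoxy in place of carboxy on an aromatic carbon. Going by the values given here, no measured pair shows what this exchange does here, and the shared core in compound 1, with a methoxy at the same position, only gave a limit. The step from compound 2 to compound 4 is therefore expected to be small, no larger than the usual scatter, as a 1.2-fold lower number from compound 2 to compound 4 (0.06 log units; within the scatter). Compound 4 is expected to give about 13000 nM in this assay, between 3500 nM and 45000 nM.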

Compound 4, half-maximal inhibitory concentration: 4000 nM
The estimate for compound 4 lay 3.3-fold (0.51 log units) above the measured number, and the stated range covers the measured number.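

In this assay, trifluoromethoxy in place of carboxy on this aromatic carbon, para to a large group, gives a 3.8-fold lower number from compound 2 to compound 4 (0.57 log units; beyond the scatter), so the result does respond to the group at this position. Carboxy carries a hydrogen-bond donor and trifluoromethoxy carries none, but a single exchange cannot tell whether that difference is what matters. Compound 1 and compound 3 each give only a limit of the assay, so neither adds a number for judging this position: the limit of > 20000 nM in this assay, at which 2 of the 4 values shown sit.

Going by these compounds, what an amine, a nitrile or a single fluorine would do at this position remains open, so two groups do not yet make a trend. On these data alone, it is also open whether the same exchange would give a similar step on the cores of compound 1 and compound 3.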